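Piperidinyl for Methoxyethylamino on Two Related Cores

This account rests on a few compounds, and the source may have more. Where it says the series, first, only, none or still open, it means among the compounds named here.

This account concerns three measured compounds and one that remains to be measured. Compound 1 `Cc1cc2c(c(N)nn2C)c(N2CCCCC2)n1` was tested in an assay on isolated protein for inhibition of ribosomal protein S6 kinase alpha-5 (Homo sapiens), read by mobility shift assay, tested at 30 uM (a lower number here means less inhibition, a higher number more inhibition at the concentration tested (going by the name of the read-out)), where compound 1 gives 7%. Compound 2 `COCCNc1nc(C)cc2c1c(N)nn2C` in this assay gives 0%. Compound 3 `COCCNc1nc(C)cc2nn(-c3ccccc3)c(N)c12` in this assay gives 3%. All three numbers lie within the usual scatter of one another, so no order among them can be read.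

Compound 2 and compound 1 differ in one place: piperidin-1-yl in place of (2-methoxyethyl)amino on an aromatic carbon This change made a step of a number 7 percentage points higher from compound 2 to compound 1 (within the scatter). Compound 4 `Cc1cc2nn(-c3ccccc3)c(N)c2c(N2CCCCC2)n1` has not yet been measured and carries the same change relative to compound 3: piperidin-1-yl in place of (2-methoxyethyl)amino on an aromatic carbon The difference between the two cores, that of compound 2 and that of compound 3, is not broken down here. Among these four compounds the change occurs twice in all.

Among the measured compounds shown here, the expectation for compound 4 rests on the single measured step of a number 7 percentage points higher from compound 2 to compound 1 (within the scatter), which stayed within the scatter. The estimated step is therefore a number 5 percentage points higher from compound 3 to compound 4 (within the scatter), again within the scatter. Compound 4 is expected to give 8% in this assay, with an estimated range from -4% to 22%.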

Compound 4, a percentage reported as inhibition, at one concentration (the size of the read-out at that concentration, not a potency): 10%
The estimate for compound 4 lay 2 percentage points below the measured number; the range from low to high includes it.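

In this assay, putting piperidin-1-yl in place of (2-methoxyethyl)amino on the core of compound 3 gave a step of a number 7 percentage points higher from compound 3 to compound 4 (within the scatter). Set beside the earlier step, the change behaves alike on both cores, with no difference between them that can be told: the same change on two cores in this assay, a number 7 percentage points higher (within the scatter) from compound 2 to compound 1 and a number 7 percentage points higher (within the scatter) from compound 3 to compound 4, 0 percentage points apart, within the scatter of two such steps Both steps lie within the scatter, however, so this agreement shows only that on neither core does the change move the number beyond what repeated measurements would allow, and it does not show that piperidin-1-yl truly adds inhibition or that a real effect of fixed size carries from one core to the other.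

The compounds shown leave open whether a different group in this place, such as a morpholine ring, a piperazine ring bearing a free amine, or a longer ether chain, would give a number beyond the scatter of these four. They also leave open whether a carboxylic acid on the phenyl ring of compound 4 would do so.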